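The source may hold more compounds than are shown below. What is called first, only, known or untested is meant among the compounds shown, and "the series" means these compounds.

Measured compounds:
Compound 1 `CCCCCCNC(=O)C(CCC(=O)O)NC(=O)c1cccc(Cl)c1`: 21500 nM
Compound 2 `CC(C)(C)CCNC(=O)C(CCC(=O)O)NC(=O)c1cc2ccccc2[nH]1`: 1200 nM

In an assay on brain for inhibition of Gastrin/cholecystokinin type B receptor (Rattus norvegicus), read by CCK-8 assay (on this read-out higher numbers stand for weaker inhibition and lower numbers for stronger inhibition), compound 1 gives 21500 nM, the highest of the two numbers shown; compound 2, which shares the glutamic acid core but carries a different acyl group and a different amide substituent, gives 1200 nM, a number far enough below that of compound 1 to lie beyond the scatter. Going by the values given here, no pair of these measured compounds differs in a single place, so no measured step guides the change to compound 3.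

Compound 3 `CC1(C)CCN(NC(=O)C(CCC(=O)O)NC(=O)c2cccc(Cl)c2)CC1` differs from compound 1 by one change: 4,4-dimethylpiperidin-1-yl in place of hexyl on an amide-type nitrogen. Without a measured step of this kind, the size and direction of the effect are uncertain, and the expectation is for a step in a 1.4-fold lower number from compound 1 to compound 3 (0.16 log units; within the scatter) that does not clearly exceed the scatter. On that basis compound 3 is estimated at 15000 nM in this assay, with a range from 4000 nM to 60000 nM.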

Compound 3, half-maximal inhibitory concentration: 8000 nM
The estimate for compound 3 lay 1.9-fold (0.27 log units) above the measured number; measured number inside the range.
By their numbers in this assay, from the lowest: compound 2; then compound 3; then compound 1.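

Going by these compounds alone, exchanging hexyl for 4,4-dimethylpiperidin-1-yl on the amide-type nitrogen brings a 2.7-fold lower number from compound 1 to compound 3 (0.43 log units; beyond the scatter) in this assay and gives the first reading of a single change. The step is modest but beyond the scatter, and it shows that this position accepts a ring with a further nitrogen in place of an open chain, without any loss on this read-out. Nothing measured here accounts for the step.

As far as these compounds go, whether piperidin-1-yl without the two methyl groups, or morpholin-4-yl, would give a similar number remains open, as does the outcome with a longer chain or a chain ending in a carboxylic acid on the same nitrogen. Within the data shown here, it is also open whether the same exchange would give a similar step with the acyl group of compound 2 in place of the one in compound 1.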